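The compounds below may be only part of what the source reports. "The series", "measured", "known", "first", "only" and "open" are said of these compounds alone.

In a functional assay on the whole organism (stomach) with Canis familiaris (Canis lupus familiaris) as the target (on this read-out lower numbers stand for an effect already at smaller amounts and higher numbers for an effect only at larger amounts of compound), compound 1 `COC(=O)CC/C=C\CC[C@H]1C(=O)C[C@@H](O)[C@@H]1/C=C/C[C@@](C)(O)C#CC1=CCCC1` gives 0.0028 mg/kg, while compound 2 `COC(=O)CC/C=C\CC[C@H]1C(=O)C[C@@H](O)[C@@H]1/C=C/C[C@@](C)(O)/C=C/C1=CCCCC1` gives 0.0003 mg/kg. Among the compounds with values here, compound 1 therefore holds the higher of the only two numbers available, and the gap lies beyond the scatter. Compound 3 `COC(=O)CC/C=C\CC[C@H]1C(=O)C[C@@H](O)[C@@H]1/C=C/CC(C)(O)CCC1=CCCC1` has not yet been measured. It keeps the core of compound 1 and its five-membered ring, and the change sits on a saturated chain carbon bound to a double-bonded chain carbon: 3-(cyclopent-1-en-1-yl)-1-hydroxy-1-methylpropyl in place of 3-(cyclopent-1-en-1-yl)-1-hydroxy-1-methylprop-2-yn-1-yl on a saturated chain carbon bound to a double-bonded chain carbon. The triple bond is lost, and the entering group has no defined stereocentre.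

Within the data shown here, only one measured step bears on this change: a 9.3-fold lower number from compound 1 to compound 2 (0.97 log units; beyond the scatter). That step also removed the triple bond, but it altered the ring as well, so the two contributions cannot be separated. Among the measured compounds shown here, no measured compound has a saturated chain at this place, which makes any forecast uncertain. A smaller move in the same direction seems the most reasonable expectation. The expected change is a 2.3-fold lower number from compound 1 to compound 3 (0.37 log units; beyond the scatter). For compound 3 the estimated value is 0.0012 mg/kg, with an expected range from 0.0003 mg/kg to 0.006 mg/kg.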

Compound 3, dose for half-maximal effect: 0.0001 mg/kg
Estimate against measurement, compound 3: 12-fold (1.08 log units) above; measured number below the stated range.
By their numbers in this assay, from the lowest: compound 3; then compound 2; then compound 1.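

With the five-membered ring kept, placing 3-(cyclopent-1-en-1-yl)-1-hydroxy-1-methylpropyl on this saturated chain carbon gives, in this assay, a 28-fold lower number from compound 1 to compound 3 (1.45 log units; beyond the scatter). The earlier step, a 9.3-fold lower number from compound 1 to compound 2 (0.97 log units; beyond the scatter), changed the ring and the chain together, whereas this one leaves the ring size alone and still produces a large drop, so an effect at smaller doses does not depend on keeping the triple bond or on having a double bond in its place. The leaving group has a defined stereocentre and the entering group has none, however, so this step carries two differences within the same group and cannot show how much of the drop belongs to each.

Nothing measured here accounts for the size of this step. Still open, going by these compounds, are how the two mirror-image forms of the entering group compare, and whether the saturated chain would hold up with a phenyl ring or a cyclohexyl ring in place of the cyclopentenyl ring.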